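Changing the Amide Group from Compound 2 to Compound 3

The compounds below may be only part of what the source reports. "The series", "measured", "known", "first", "only" and "open" are said of these compounds alone.

Compound 1 `Cc1ccc(-c2cc(C(=O)Nc3ccc(Cl)nc3Cl)nn2-c2ccc3ccccc3n2)cc1`: 14000 nM
Compound 2 `COc1ncccc1NC(=O)c1cc(-c2ccc(C)cc2)n(-c2ccc3ccccc3n2)n1`: 7900 nM
Compound 3 `Cc1ccc(-c2cc(C(=O)NCc3cccnc3)nn2-c2ccc3ccccc3n2)cc1`: not yet measured

Both values come from a functional assay on Huh-7 cells (Homo sapiens) for cytotoxicity, read by sulforhodamine B assay, with a stated time of 72 h; a lower number here means a stronger inhibitor, a higher number a weaker inhibitor. Compound 2 stands level with compound 1, and neither can be ranked over the other. Compound 3 carries (pyridin-3-yl)methyl in place of 2-methoxypyridin-3-yl on an amide-type nitrogen. Among the measured compounds shown here, only one measured step bears on this change, as it also exchanged a group on that nitrogen. That step was small, a 1.8-fold lower number from compound 1 to compound 2 (0.25 log units; within the scatter). It involved no (pyridin-3-yl)methyl group, however, so it offers only a loose guide and the range must stay wide. No step beyond the scatter is expected in this assay. The expected step is a 1.5-fold higher number from compound 2 to compound 3 (0.18 log units; within the scatter). For compound 3 the estimated value is 12000 nM, with an expected range from 4000 nM to 35000 nM.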

Compound 3, half-maximal inhibitory concentration: 14100 nM
Compound 3: the middle estimate sits 1.2-fold (0.07 log units) below what was measured, and the stated range covers the measured number.
By their numbers in this assay, from the lowest: compounds 2, 1 and 3 (each within the scatter of the next).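

In this assay the (pyridin-3-yl)methyl group on the amide-type nitrogen gives a 1.8-fold higher number from compound 2 to compound 3 (0.25 log units; within the scatter) and a 1.0-fold higher number from compound 1 to compound 3 (0.00 log units; within the scatter) and so stands level with both earlier groups. The earlier pair covered only 2,6-dichloropyridin-3-yl and 2-methoxypyridin-3-yl, whereas this result shows that a group of a different kind, with its ring held through a methyl link, also stays within the scatter, so none of the three groups can be ranked at this position. No evidence is available on why these compounds read alike.

As far as these compounds go, whether a 2-(pyridin-3-yl)ethyl chain, a plain phenyl ring or a cyclohexyl ring on this nitrogen would move the number beyond the scatter remains open. The compounds shown also leave open whether any group at this position can give a clearly lower number.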